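The source may hold more compounds than are shown below. What is called first, only, known or untested is meant among the compounds shown, and "the series" means these compounds.

Measured so far:
compound 1 `CCOC(=O)c1nn(-c2ccccc2)c(-c2ccc(OC)cc2OC)c1-c1ccccc1` — 20.5%
compound 2 `COc1ccc(C2=NN(C(=O)NS(=O)(=O)c3ccc(Cl)cc3)CC2c2ccccc2)c(OC)c1` — 27.3%
compound 3 `COc1ccc(C2=NN(C(=O)NS(=O)(=O)c3ccc(Cl)cc3)CC2C)c(OC)c1` — 14.6%

All three were read in a functional assay on the whole organism (strain albino) for inhibition, with Rattus norvegicus as the target, read by paw edema, with stated times of 30 min and 2 h, at a dose of 25 mg/kg by the intraperitoneal route; a lower number here means less inhibition, a higher number more inhibition at the dose given (going by the name of the read-out). Compound 2 holds the highest of the three numbers, but compound 1 lies within the scatter of it, so no order between those two is claimed. Compound 3 lies beyond the scatter: the step is a number 12.7 percentage points lower from compound 2 to compound 3 (beyond the scatter), and it comes with a change on a saturated ring carbon of the shared core.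

Compound 4 `COc1ccc(C2=NN(C(=O)NS(=O)(=O)c3ccc(C)cc3)CC2c2ccccc2)c(OC)c1` is the next compound and differs from compound 2 in one place: methyl in place of chloro on an aromatic carbon. Among the measured compounds shown here, no measured pair differs at the aromatic ring attached to the sulfonyl group, so no measured step bears directly on this change; the one step known, a number 12.7 percentage points lower from compound 2 to compound 3 (beyond the scatter), concerns a different part of the molecule and gives no guidance here. With nothing to suggest a shift, the expectation is a step no larger than the scatter, in either direction: a number 2.3 percentage points lower from compound 2 to compound 4 (within the scatter) is the estimated change. Compound 4 is therefore expected to give about 25% in this assay, with a range of 12% to 38%.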

Compound 4, a percentage reported as inhibition, in the whole organism at one dose (the size of the read-out at that dose, not a potency): 6.33%
For compound 4 the middle estimate is 18.7 percentage points above the measured one, and the stated range ends above it.
By their numbers in this assay, from the lowest: compounds 4, 3, 1 and 2 (each within the scatter of the next, the first and the last beyond it).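

In this assay, among the compounds shown here, going from 4-chlorophenyl to 4-methylphenyl on the sulfonyl group gives a number 21 percentage points lower from compound 2 to compound 4 (beyond the scatter), the first reading at a place the earlier compounds left unchanged. The swap replaces one heavy atom with one heavy atom, with no change in counted hydrogen-bond donors, acceptors or net charge, yet the step lies beyond the scatter. This aromatic position therefore joins the saturated ring carbon, where the step is a number 12.7 percentage points lower from compound 2 to compound 3 (beyond the scatter), as a second place in the series where one change moves the read-out, and nothing at hand explains the size of the new step.

As far as these compounds go, whether chloro is unusual here or methyl is the poor fit remains open, since a fluoro, nitrile or amine at this carbon would separate the two readings. Also open, from the compounds shown here alone, is whether the same swap gives a similar step when methyl stands on the saturated ring carbon.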